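From isopentyl to butyl on a shared core

The source may hold more compounds than are shown below. What is called first, only, known or untested is meant among the compounds shown, and "the series" means these compounds.

In a functional assay on EOL1 cells (Homo sapiens) for inhibition, read by fluorescence, with a stated time of 72 h (a higher number here means a weaker inhibitor of growth, a lower number a stronger inhibitor of growth), compound 1 `CC(C)CCn1cnc2c(Nc3ccc(Cl)cc3)nc(N[C@H]3CC[C@H](N)CC3)nc21` gives 90 nM and compound 2 `CCCCn1cnc2c(NCc3cccc(Cl)c3)nc(N[C@H]3CC[C@H](N)CC3)nc21` gives 350 nM while compound 3 `COc1cc(Nc2nc(N[C@H]3CC[C@H](N)CC3)nc3c2ncn3CCC(C)C)cc(OC)c1` gives 140 nM as the second highest of the three numbers. That places compound 3 level with compound 1 within the normal spread of repeat measurements, and the value of compound 2 is clearly higher than both.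

The move to compound 4 `CCCCn1cnc2c(Nc3cc(OC)cc(OC)c3)nc(N[C@H]3CC[C@H](N)CC3)nc21` is hydrogen in place of methyl on a saturated chain carbon bound to two saturated chain carbons and amounts to hydrogen in place of methyl on a saturated chain carbon bound to two saturated chain carbons, turning isopentyl into butyl. Among the compounds with values here, no measured step covers this change. Within the data shown here, the one available step is a 1.6-fold higher number from compound 1 to compound 3 (0.19 log units; within the scatter) and it concerns 3,5-dimethoxyphenyl in place of 4-chlorophenyl, not the chain. The butyl chain also occurs in compound 2 at 350 nM but that compound differs elsewhere as well, so its number does not isolate the chain.

Among the measured compounds shown here, with no measured chain step to go on, the expectation starts from compound 3 at 140 nM and allows only a small shift. The expected move is a 1.1-fold higher number from compound 3 to compound 4 (0.06 log units; within the scatter) and that is no step beyond the scatter in this assay for this pair. The estimated value for compound 4 is 160 nM with an expected range from 75 nM to 340 nM for repeat measurements.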

Compound 4, concentration for 50% growth inhibition: 370 nM
Estimate against measurement, compound 4: 2.3-fold (0.36 log units) below, and the stated range ends below it.
By their numbers in this assay, from the lowest: compounds 1 and 3 (each within the scatter of the next); then compounds 2 and 4 (each within the scatter of the next).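

In this assay, hydrogen in place of methyl on a saturated chain carbon bound to two saturated chain carbons, which turns isopentyl into butyl, gives a 2.6-fold higher number from compound 3 to compound 4 (0.42 log units; beyond the scatter). Within the data shown here, this is the first measured step at the chain, and it shows that removing this methyl matters here while the 3,5-dimethoxyphenyl group stays fixed. With butyl held constant, 3,5-dimethoxyphenyl in place of 3-chlorobenzyl on a nitrogen on an aromatic ring gives a 1.1-fold higher number from compound 2 to compound 4 (0.02 log units; within the scatter), and with isopentyl held constant, the change from 4-chlorophenyl gives a 1.6-fold higher number from compound 1 to compound 3 (0.19 log units; within the scatter), so both steps at that nitrogen stay within the scatter and the chain step alone goes beyond it; no measurement shown gives a reason for this difference.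

The compounds shown leave open whether the same methyl change would have a similar effect with 4-chlorophenyl or 3-chlorobenzyl on the nitrogen. They also leave open how the growth-inhibition number would respond to a longer chain such as hexyl, or to a chain ending in a hydroxyl group.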